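One stereocentre flipped in a fluorinated chain

The source may report more compounds than this note shows. Statements on the series, on what has been measured and on what is new or still open speak of the compounds shown alone.

Going by the values given here, in a functional assay on HeLa cells (Homo sapiens) for cytotoxicity, read by WST assay, with a stated time of 48 h (on this read-out lower numbers stand for stronger inhibition and higher numbers for weaker inhibition), compound 1 (`COc1cc(C(c2ccc(O)c(OC)c2)[C@H](C)C(C)C)ccc1O`) gives 16000 nM as the lowest number so far. Compound 2 (`COC[C@H](C)[C@@H](C)C(c1ccc(O)c(OC)c1)c1ccc(O)c(OC)c1`) gives 77000 nM as its value. Compound 3 (`COc1cc(C(c2ccc(O)c(OC)c2)[C@H](C)[C@H](C)CF)ccc1O`) gives 75000 nM as its value, level with compound 2 and higher than compound 1. Compound 4 (`COc1cc(C(c2ccc(O)c(OC)c2)[C@H](C)[C@@H](C)CF)ccc1O`) differs from compound 3 in configuration only (the two compounds have the same atoms and bonds and differ only in configuration as drawn: 1 of 2 stereo elements differ; a stereocentre at a saturated chain carbon is drawn S in compound 3 and R in compound 4) and no atom enters or leaves. Adding a group to the chain gave a 4.7-fold higher number from compound 1 to compound 3 (0.67 log units; beyond the scatter) for fluoro and a 4.8-fold higher number from compound 1 to compound 2 (0.68 log units; beyond the scatter) for methoxy, both modest, while exchanging those chains gave a 1.0-fold lower number from compound 2 to compound 3 (0.01 log units; within the scatter) within the scatter. Among the compounds with values here, no measured step tests configuration alone. The expected change is a 1.2-fold lower number from compound 3 to compound 4 (0.06 log units; within the scatter) in this assay and thus none beyond the scatter. Compound 4 is estimated at 65000 nM with 28000 nM to 130000 nM as the expected range.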

Compound 4, half-maximal inhibitory concentration: 34000 nM
Beside the measured number, compound 4's estimate is 1.9-fold (0.28 log units) above it; the measured number falls inside the stated range.
By their numbers in this assay, from the lowest: compound 1; then compound 4; then compounds 3 and 2 (each within the scatter of the next).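

In this assay, going by these compounds alone, the step of a 2.2-fold lower number from compound 3 to compound 4 (0.34 log units; beyond the scatter) is the first to show that the drawn configuration at this saturated chain carbon can move the number on its own: the fact that compounds 3 and 4 differ only in the configuration as drawn. With the configuration of compound 4, fluoro in place of methoxy also gives a step beyond the scatter, a 2.3-fold lower number from compound 2 to compound 4 (0.36 log units; beyond the scatter), whereas a 1.0-fold lower number from compound 2 to compound 3 (0.01 log units; within the scatter) stayed within it. Fluoro in place of hydrogen likewise gives a smaller step here, a 2.1-fold higher number from compound 1 to compound 4 (0.33 log units; beyond the scatter), than a 4.7-fold higher number from compound 1 to compound 3 (0.67 log units; beyond the scatter).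

Going by these compounds, whether flipping this stereocentre would shift the number for the methoxy chain remains open. So does what it would do with a hydroxyl or a chloro group on the same chain carbon.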